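The source may report more compounds than this note shows. Statements on the series, on what has been measured and on what is new or still open speak of the compounds shown alone.

The measured compounds in a functional assay on Hep 3B2 cells (Homo sapiens) for antiproliferative activity, read by MTT assay, with a stated time of 24 h, tested at 1.23 ug/mL; a higher number here means a stronger effect of the compound at the concentration tested, a lower number a weaker effect:

compound 1, `Cc1c(C(=O)Nc2c(F)cc(-c3cccc(F)c3)cc2F)nc2ccc(F)cc2c1O`, gives 15.3%
compound 2, `Cc1c(C(=O)Nc2c(F)cc(-c3cccc(F)c3)cc2F)nc2ccc(C(F)(F)F)cc2c1O`, gives 15.3%
compound 3, `Cc1c(C(=O)Nc2c(F)cc(-c3cccc(F)c3)cc2F)nc2ccc(F)cc2c1C(=O)O`, gives 2.45%

Compound 3 has the lowest of the three numbers in this assay; the step of a number 12.9 percentage points lower from compound 1 to compound 3 (beyond the scatter), carboxy in place of hydroxy on an aromatic carbon, lies beyond the scatter, and compound 2 sits the same distance above it. The step now considered leads from compound 3 to compound 4, `COc1ccc2nc(C(=O)Nc3c(F)cc(-c4cccc(F)c4)cc3F)c(C)c(C(=O)O)c2c1`. The change is methoxy in place of fluoro on an aromatic carbon. Among the measured compounds shown here, the one measured step that touches the same place is no change at the digits printed from compound 1 to compound 2 (within the scatter), where trifluoromethyl in place of fluoro left the number unchanged within the scatter. On that basis a swap at the same position is expected to move this assay little, if at all, and compound 3 already sits near the bottom of the scale. The expected step is a number 1.6 percentage points higher from compound 3 to compound 4 (within the scatter). Compound 4 is therefore estimated at 4%, within a range from 0% to 15%.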

Compound 4, a percentage reported as inhibition, at one concentration (the size of the read-out at that concentration, not a potency): 1.05%
Compound 4: middle estimate off by 3 percentage points, on the high side, within the range that was stated.
By their numbers in this assay, from the lowest: compounds 4 and 3 (each within the scatter of the next); then compounds 1 and 2 (each within the scatter of the next).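

In this assay methoxy in place of fluoro gives a number 1.4 percentage points lower from compound 3 to compound 4 (within the scatter) and so adds a second swap at this aromatic carbon that stays within the scatter, this time on a compound carrying carboxy rather than hydroxy, where the earlier swap gave no change at the digits printed from compound 1 to compound 2 (within the scatter) on hydroxy compounds. The reading is limited, however, since compound 3 gives 2.45% and compound 4 gives 1.05% in this assay, both close to the bottom of the scale, where little room remains to see any further loss. Nothing measured here explains this result.

Going by these compounds, it remains open whether an amine or a longer chain such as butoxy on this aromatic carbon would move the number beyond the scatter. Also open, on these data alone, is whether methoxy would behave the same way with hydroxy in place of carboxy, where the number starts higher.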